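The compounds below may be only part of what the source reports. "The series", "measured", "known", "first", "only" and "open" are said of these compounds alone.

In a functional assay on NCI-H460 cells (Homo sapiens) for inhibition, read by MTT assay, with a stated time of 24 h, tested at 100 ug/mL (on this read-out higher numbers stand for more inhibition of growth at the one concentration tested and lower numbers for less inhibition of growth), compound 1 (`O=C(CCCCC(S)CCS)Nc1ccccc1`) gives 25.4% and compound 2 (`O=C(CCCCC(S)CCS)Nc1ccc(F)cc1`) gives 41.6%, the higher of the two measured numbers. Still unmeasured is compound 3 (`O=C(CCCCC(S)CCS)Nc1ccc([N+](=O)[O-])cc1`), with nitro in place of fluoro on an aromatic carbon, para to a large group: nitro in place of fluoro on an aromatic carbon. For the measured compounds named here, the only measured step bearing on this change is a number 16.2 percentage points higher from compound 1 to compound 2 (beyond the scatter), which came with fluoro in place of hydrogen on an aromatic carbon. Going by the values given here, that single step does not show how nitro compares with fluoro, and no measured compound carries nitro. No clear direction can be drawn from these data, so a step within the scatter is expected in this assay, with wide uncertainty: a number 1.6 percentage points lower from compound 2 to compound 3 (within the scatter). Compound 3 is estimated at 40%, with an expected range of 20% to 62%.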

Compound 3, percent growth inhibition at one concentration: 39.1%
Compound 3: middle estimate off by 0.9 percentage points, on the high side; measured number inside the range.
By their numbers in this assay, from the lowest: compound 1; then compounds 3 and 2 (each within the scatter of the next).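

In this assay, nitro in place of fluoro on an aromatic carbon, para to a large group, gives a number 2.5 percentage points lower from compound 2 to compound 3 (within the scatter), so these two groups are not separated at this position despite the difference of three heavy atoms and two hydrogen-bond acceptors against one heavy atom and none. Nitro in place of hydrogen gives a number 13.7 percentage points higher from compound 1 to compound 3 (beyond the scatter), so the step away from hydrogen beyond the scatter is no longer seen with fluoro alone; among the three compounds, none goes against this. No measurement of any property of these groups is at hand to account for this result.

Open, from the compounds shown here alone, is whether an amine or a carboxylic acid on the same aromatic carbon would stand with fluoro and nitro or with hydrogen. Also open, going by these compounds, is what a longer chain on the shared core would give in this assay.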